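Adding a fluoro to the phenyl of compound 3

This account rests on a few compounds, and the source may have more. Where it says the series, first, only, none or still open, it means among the compounds named here.

Compound 3 `COc1cc(N(CC2CC2)c2ccc(F)c(Cl)c2)cnc1C(=O)[C@H]1C[C@@H]1C(=O)O` gives 3.1 uL/min in an ADME assay on cells (Hepatocyte, Homo sapiens) for metabolic stability, read by LC-MS, with a stated time of 60 min, tested at 1 uM; a lower number here means slower removal, a higher number faster removal of the compound; its number is the second highest of the three shown, though within the scatter of both others. Compound 2 `COc1cc(N(CC2CC2)c2cccc(C(F)(F)F)c2)cnc1C(=O)[C@H]1C[C@@H]1C(=O)O` gives 2.3 uL/min and compound 1 `COc1cc(N(CC2CC2)c2ccc(Cl)c(Cl)c2)cnc1C(=O)[C@H]1C[C@@H]1C(=O)O` gives 4.3 uL/min. Compound 4 `COc1cc(N(CC2CC2)c2cc(Cl)c(F)cc2F)cnc1C(=O)[C@H]1C[C@@H]1C(=O)O` differs from compound 3 by fluoro in place of hydrogen on an aromatic carbon. The measured steps that bear on it are the other changes on the phenyl: a 1.4-fold lower number from compound 1 to compound 3 (0.14 log units; within the scatter), a 1.9-fold lower number from compound 1 to compound 2 (0.27 log units; within the scatter) and a 1.3-fold higher number from compound 2 to compound 3 (0.13 log units; within the scatter), all within the scatter. Since no halogen change on this phenyl has moved this assay beyond the scatter, none is expected here either, and the expected step is no change at the digits printed from compound 3 to compound 4 (within the scatter). Compound 4 is therefore estimated at 3.1 uL/min, with a range of 1.6 uL/min to 6.2 uL/min.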

Compound 4, intrinsic clearance in a liver preparation (reported as CLH), per the amount of preparation that the assay uses in the Hepatocyte assay: < 1.5 uL/min
Compound 4: a limit, no number; the forecaster's own chance of this, stated with the estimate: 0%; middle value at least 2.0-fold (0.31 log units) from the limit.
By their numbers in the Hepatocyte assay, from the lowest: compounds 2, 3 and 1 (each within the scatter of the next). At a limit, below all of these: compound 4.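

Fluoro in place of hydrogen, ortho to a large group, moves the number beyond the scatter in the Hepatocyte assay, unlike the steps among compounds 1, 2 and 3: an at least 2.0-fold lower number from compound 3 to compound 4 (0.31 log units; beyond the scatter) and an at least 2.8-fold lower number from compound 1 to compound 4 (0.45 log units; beyond the scatter), though an at least 1.5-fold lower number from compound 2 to compound 4 (0.18 log units; that floor lies within the scatter). For compound 4 the reading is a limit, not a number: the limit of < 1.5 uL/min in the Hepatocyte assay, at which 1 of the 4 values shown sits.

In a physicochemical assay for lipophilicity, read by LC-MS, in phosphate buffer, measured as octanol-water partition, at pH 7.4 (on this read-out higher numbers stand for higher lipophilicity and lower numbers for lower lipophilicity), compound 3 gives 1.2 and compound 4 gives 1.1, values within the scatter of each other.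

On these data alone, how far under its limit compound 4 lies remains open. So does whether a nitrile or a methyl in place of this fluoro would give a step of similar size.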